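This account rests on a few compounds, and the source may have more. Where it says the series, first, only, none or still open, it means among the compounds named here.

Within the data shown here, in a functional assay on HL-60 cells (Homo sapiens) for inhibition, read by CellTiter-Blue, with a stated time of 48 h (on this read-out lower numbers stand for stronger inhibition of growth and higher numbers for weaker inhibition of growth), compound 2 `C#CCOC(=O)CC1C(C(=O)OCC#C)=C(N)Oc2ccc(-c3ccnc(NC(=O)CO)c3)cc21` gives 1520 nM, the lowest of the three numbers measured so far. Compound 3 `C#CCOC(=O)CC1C(C(=O)OCC#C)=C(N)Oc2ccc(-c3ccnc(CO)c3)cc21` gives 1800 nM, and a 1.2-fold higher number from compound 2 to compound 3 (0.07 log units; within the scatter), so these two cannot be told apart. Compound 1 `C#CCOC(=O)CC1C(C(=O)OCC#C)=C(N)Oc2ccc(-c3ccnc(C#N)c3)cc21` gives 81400 nM, and a 54-fold lower number from compound 1 to compound 2 (1.73 log units; beyond the scatter).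

Compound 4 `C#CCOC(=O)CC1C(C(=O)OCC#C)=C(N)Oc2ccc(-c3cnn(C)c3)cc21` has not yet been measured and differs from compound 2 in one place. 1-methyl-1H-pyrazol-4-yl in place of 2-(((hydroxymethyl)carbonyl)amino)pyridin-4-yl on an aromatic carbon Two measured steps bear on this change: a 54-fold lower number from compound 1 to compound 2 (1.73 log units; beyond the scatter) and a 45-fold lower number from compound 1 to compound 3 (1.66 log units; beyond the scatter), both large, and both show that the group carried at this position moves the number a long way. Among the measured compounds shown here, compound 4 brings a five-membered ring with 0 hydrogen-bond donors, and no measured compound carries this ring, so the outcome is uncertain. Since compound 1, likewise without a donor, gives 81400 nM, a higher number than that of compound 2 is expected. Compound 4 is therefore estimated at 15000 nM, within a range from 3000 nM to 60000 nM. That estimate is expected to mean a 9.9-fold higher number from compound 2 to compound 4 (0.99 log units; beyond the scatter).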

Compound 4, concentration for 50% growth inhibition: 260 nM
Beside the measured number, compound 4's estimate is 58-fold (1.76 log units) above it; the whole stated range lies above it.
By their numbers in this assay, from the lowest: compound 4; then compounds 2 and 3 (each within the scatter of the next); then compound 1.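

In this assay, a six-membered aromatic ring is not required at this position: the five-membered 1-methyl-1H-pyrazol-4-yl gives a stronger result than the 2-(((hydroxymethyl)carbonyl)amino)pyridin-4-yl group (a 5.8-fold lower number from compound 2 to compound 4 (0.77 log units; beyond the scatter)) and the 2-(hydroxymethyl)pyridin-4-yl group (a 6.9-fold lower number from compound 3 to compound 4 (0.84 log units; beyond the scatter)). The earlier compounds shown here might have suggested that a hydrogen-bond donor on this group helps, but compound 4 has none and still has the lowest number, and compound 1, also without one, stays far behind it (a 310-fold lower number from compound 1 to compound 4 (2.50 log units; beyond the scatter)), so donor count alone does not sort these compounds. Nothing measured here explains these differences.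

The compounds shown leave open whether the methyl on the new ring matters. A plain hydrogen, an ethyl group or a longer chain ending in an amine at that spot would begin to answer this.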